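The source may report more compounds than this note shows. Statements on the series, on what has been measured and on what is new or still open speak of the compounds shown alone.

Measured so far:
compound 1, `CNC(=O)c1cc(Oc2ccc(C(=O)/C=C/c3ccc(F)cc3Cl)cc2)ccn1`, in a functional assay on PC-3 cells (Homo sapiens) for cytotoxicity, read by MTT assay, with a stated time of 72 h; on this read-out higher numbers stand for weaker inhibition and lower numbers for stronger inhibition: 4760 nM
compound 2, `CNC(=O)c1cc(Oc2ccc(C(=O)/C=C/c3ccc(F)cc3)cc2)ccn1`, in this assay: 6140 nM
compound 3, `CNC(=O)c1cc(Oc2ccc(C(=O)/C=C/c3ccco3)cc2)ccn1`, in this assay: "not determined" (no result reported)

All three share one core; they differ only in the aromatic group at the far end of the double-bonded chain. For the measured compounds named here, compounds 1 and 2 carry a substituted benzene ring there and give similar numbers, the step of a 1.3-fold higher number from compound 1 to compound 2 (0.11 log units; within the scatter) being the only comparison available. Compound 3, which carries furan-2-yl instead, has no number at all, so it offers no anchor of its own on this read-out.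

Compound 4, `CNC(=O)c1cc(Oc2ccc(C(=O)/C=C/c3ccc(Cl)c(Cl)c3)cc2)ccn1`, is the next compound to be measured. Relative to compound 3 its change is 3,4-dichlorophenyl in place of furan-2-yl on a double-bonded chain carbon bound to a double-bonded chain carbon. Going by the values given here, no measured pair covers a swap of a five-membered ring for a six-membered one, so the only guide is that the two benzene-bearing compounds 1 and 2 sit close together, and the step of a 1.3-fold higher number from compound 1 to compound 2 (0.11 log units; within the scatter) shows that changing one chlorine on that ring moved the number little. On that basis compound 4, which again carries a chlorinated benzene ring, is expected to land near compounds 1 and 2, with a wide range to reflect the missing anchor for compound 3.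

Compound 4 is therefore estimated at 4500 nM, expected to fall between 1500 nM and 13000 nM.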

Compound 4, half-maximal inhibitory concentration: 8260 nM
Compound 4: the middle estimate sits 1.8-fold (0.26 log units) below what was measured; low and high end bracket the measured number.
By their numbers in this assay, from the lowest: compounds 1, 2 and 4 (each within the scatter of the next).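

In this assay, putting 3,4-dichlorophenyl on the double-bonded chain carbon gives a 1.3-fold higher number from compound 2 to compound 4 (0.13 log units; within the scatter) and also a 1.7-fold higher number from compound 1 to compound 4 (0.24 log units; within the scatter) when the comparison starts from the other benzene-bearing compound. The earlier pair showed only that removing one chlorine from the ring made no clear difference, whereas these steps show that a ring with a different halogen pattern also stays within the scatter, so 2-chloro-4-fluorophenyl, 4-fluorophenyl and 3,4-dichlorophenyl cannot be told apart at this place on this read-out. Compound 3 has no reported number, so its step to compound 4 cannot be read, and the change from furan-2-yl to 3,4-dichlorophenyl remains without a size.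

No supporting data bear on why these three rings give such similar results. The compounds shown leave open whether a benzene ring carrying an amine or a carboxylic acid, rather than chlorine or fluorine, would give a number in the same range in this assay.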